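Thiourea in place of cyanobenzyl on the shared core

A few compounds are considered here, and "the series" means these few. Any claim that something is new, unique, unknown or untested is made for them only; others in the source may bear on it.

The series shares one core, seen in compound 1 `N#Cc1ccccc1CN1CCc2c(sc(NC(=O)c3ccccc3Cl)c2C(N)=O)C1`. In a functional assay on MKN-74 cells (Homo sapiens) for antiproliferative activity, with a stated time of 24 h (a higher number here means a weaker inhibitor, a lower number a stronger inhibitor), compound 1 gives 9500 nM. Compound 3 `Cc1ccc(C(=O)Nc2sc3c(c2C(N)=O)CCN(Cc2c(Cl)cccc2Cl)C3)cc1` gives 12300 nM in this assay, and the two numbers lie within the usual scatter of each other. For compound 2 `NC(=O)c1c(NC(=O)c2ccc(C(F)(F)F)cc2)sc2c1CCN(Cc1ccc(Cl)cc1)C2` this assay reports only a limit, > 50000 nM, and so no number (the limit of > 50000 nM in this assay, at which 1 of the 3 values shown sits). Compound 4 `NC(=O)c1c(NC(=O)c2ccccc2Cl)sc2c1CCN(C(=S)Nc1ccccc1)C2` differs from compound 1 in one place: a group of 9 heavy atoms (7 carbon, 1 nitrogen, 1 sulfur; one six-membered aromatic ring of carbon only) in place of a group of 9 heavy atoms (8 carbon, 1 nitrogen; one six-membered aromatic ring of carbon only), on an amine nitrogen in a ring, on an amine nitrogen in a ring. Among the compounds with values here, no measured pair shows such a change, so the size of the step is open. Compound 4 is expected to give about 15000 nM in this assay, within 4000 nM to 60000 nM, a step that is estimated as a 1.6-fold higher number from compound 1 to compound 4 (0.20 log units; within the scatter), not clearly beyond the scatter.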

Compound 4, half-maximal inhibitory concentration: 15600 nM
Compound 4: the middle estimate sits 1.0-fold (0.02 log units) below what was measured; the range from low to high includes it.
By their numbers in this assay, from the lowest: compounds 1, 3 and 4 (each within the scatter of the next). At a limit, above all of these: compound 2.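

In this assay, placing the thiourea group on the amine nitrogen in a ring in place of 2-cyanobenzyl gives a 1.6-fold higher number from compound 1 to compound 4 (0.22 log units; within the scatter) and so no change that can be told from scatter. Within the data shown here, this is the first single change at this position that can be read, and it shows that the benzyl group can give way to this thiourea group with no clear change in the number.

Going by these compounds, whether a urea, an amine or an alkyl chain in place of the phenyl ring on the thiourea would behave the same stays open. Nothing measured here bears on the reason for this step.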